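The source may hold more compounds than are shown below. What is called first, only, known or untested is meant among the compounds shown, and "the series" means these compounds.

Working notes on the series, read in an ADME assay on MDCK cells (Canis lupus familiaris) for cytotoxicity, read by MTT assay, with a stated time of 48 h; a lower number here means that less compound is tolerated, a higher number that more compound is tolerated. For the measured compounds named here, compound 1 (`COC(=O)[C@H](CC(C)C)NC(=O)CSc1nc(-c2ccccc2)cc(-c2ccc(C)cc2)c1C#N`) gives 215000 nM, the only true number so far. Compound 2 (`CC[C@H](C)[C@H](NC(=O)CSc1nc(-c2ccccc2)cc(-c2ccc(C)cc2)c1C#N)C(=O)OC`) reads > 250000 nM, which is a limit and not a number. Compound 3 (`Cc1ccc(-c2cc(-c3ccccc3)nc(SCC(=O)N[C@H](C(=O)O)C(C)C)c2C#N)cc1`) reads > 250000 nM, which is also a limit and not a number. Compound 3 therefore has no exact place in the series and sits at the limit of > 250000 nM in this assay, at which 2 of the 3 values shown sit.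

Compound 4 (`Cc1ccc(-c2cc(-c3ccccc3)nc(SCC(=O)O)c2C#N)cc1`) differs from compound 3 as follows: hydroxy in place of (1-carboxy-2-methylpropyl)amino on a carbonyl carbon. In words, this is hydroxy in place of (1-carboxy-2-methylpropyl)amino on a carbonyl carbon.

Going by the values given here, no measured step removes that whole group. The nearest evidence is an at least 1.1-fold higher number from compound 1 to compound 3 (0.06 log units; that floor lies within the scatter), which changes the substituent on the same amide-type nitrogen, and an at least 1.1-fold higher number from compound 1 to compound 2 (0.06 log units; that floor lies within the scatter), a change within the side chain. Neither floor goes beyond the scatter. The remaining step, a step that the two limits leave unreadable from compound 2 to compound 3, gives no size at all.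

With compound 1 at 215000 nM and no measured step shown beyond the scatter, no clear move in either direction is expected. For compound 4 the expected step is an at least 1.0-fold lower number from compound 3 to compound 4 (0.01 log units; that floor lies within the scatter), which would stay within the scatter. For compound 4 the estimated value is 240000 nM, with an expected range of 120000 nM to 450000 nM.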

Compound 4, half-maximal cytotoxic concentration: > 250000 nM
Compound 4: a limit, no number; the forecaster's own chance of this, stated with the estimate: 60%; middle value at least 1.0-fold (0.01 log units) from the limit.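

In this assay compound 4 reads > 250000 nM, which is a limit and not a number. The change on this carbonyl carbon removes the whole (1-carboxy-2-methylpropyl)amino group and leaves hydroxy, yet the result stays at the same limit, so a compound without that group or any amide-type nitrogen at this place still gives no true number. The one readable step is an at least 1.1-fold higher number from compound 1 to compound 4 (0.06 log units; that floor lies within the scatter), while the steps that join one limit to another cannot be read, and the series now stands mostly at a single limit: the limit of > 250000 nM in this assay, at which 3 of the 4 values shown sit.

From the compounds shown here alone, what stays open is how far compounds 2, 3 and 4 differ from one another, since none of them has a true number, and so the size of the change on this carbonyl carbon remains unknown. Going by these compounds, it is also open whether an amine or a longer chain in place of hydroxy on this carbonyl carbon would give a true number in this assay.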